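Ethyl-for-methyl on the core: expectation for compound 3

The compounds below may be only part of what the source reports. "The series", "measured", "known", "first", "only" and "open" are said of these compounds alone.

Compound 1 `Cc1ccc2nc(NC(=S)NC3CCCCC3)sc2c1` carries a cyclohexyl on the amide-type nitrogen; in a functional assay (thoracic aorta, Rattus norvegicus, strain Wistar) (a higher number here means that more compound is needed for the effect, a lower number that less compound is needed), compound 1 gives 52100 nM. Compound 2 `Cc1ccc2nc(NC(=S)NCc3ccccc3)sc2c1` has a benzyl in that place. In this assay compound 2 gives > 100000 nM, which is a limit of the assay and not a number. The step of an at least 1.9-fold higher number from compound 1 to compound 2 (0.28 log units; that floor lies within the scatter) is therefore only a floor, and it sits at the limit of > 100000 nM in this assay, at which 1 of the 2 values shown sits. Compound 2 thus stands at the edge of what this assay can report, with no number of its own.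

Compound 3 `CCc1ccc2nc(NC(=S)NCc3ccccc3)sc2c1` differs from compound 2 by methyl in place of hydrogen on a saturated chain carbon bound to an aromatic carbon; read one bond further out, the change is methyl to ethyl on the shared core. Among the compounds with values here, no measured step touches this position: the single step from compound 1 to compound 2 concerns the amide-type nitrogen, not the core substituent, so it offers no guide to size or direction here. With compound 2 already at the limit, compound 3 is expected to show a step that the limit leaves unreadable from compound 2 to compound 3, that is none beyond the scatter. The estimate for compound 3 in this assay is 120000 nM, within 50000 nM to 300000 nM, and it is expected that the assay most likely again reports only a limit.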

Compound 3, half-maximal effective concentration: > 100000 nM
Compound 3 ended at the assay's limit; the forecaster's own chance of this, stated with the estimate: 75%; the middle value is on the limit's open side.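

In this assay compound 3 gives > 100000 nM, which is a limit of the assay and not a number. Compound 2 also stands at a limit, so no step between compound 2 and compound 3 can be read: the limit of > 100000 nM in this assay, at which 2 of the 3 values shown sit.

The compounds shown leave open how methyl to ethyl on the shared core shifts the number in this assay.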